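A few compounds are considered here, and "the series" means these few. Any claim that something is new, unique, unknown or untested is made for them only; others in the source may bear on it.

Measured so far in a functional assay on RKE cells for antagonist activity at Vasoactive intestinal polypeptide receptor 1 (Rattus norvegicus), read by HTRF and cAMP accumulation, with stated times of 10 min and 30 min; on this read-out lower numbers stand for stronger inhibition and higher numbers for weaker inhibition:
compound 1 `CCC(=O)Nc1sc2c(c1C#N)CCCC2` gives 12000 nM
compound 2 `CC(C)c1cc(C(C)(C)C)cc(-c2cccc(-c3ccccc3)c2)c1CO` gives 210 nM
compound 3 `CC(=O)Nc1sc2c(c1C#N)CCCC2` gives 13000 nM

Compound 3 stands highest of the three numbers in this assay. For the measured compounds named here, its nearest neighbour is compound 1, the only one that shares its core and differs in one place; the step of a 1.1-fold higher number from compound 1 to compound 3 (0.03 log units; within the scatter) lies within the scatter, so the two values cannot be ordered. Going by the values given here, compound 2, built on a different core, stands far lower, and that gap is beyond the scatter; no single-point step links it to compound 3, so its value only shows that this assay can report much lower numbers.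

The next compound, compound 4 `N#Cc1c(NC(=O)C2CC2)sc2c1CCCC2`, differs from compound 3 by cyclopropyl in place of methyl on a carbonyl carbon; cut one bond further out, the change reads acetyl to cyclopropylcarbonyl. Among the compounds with values here, the only measured step bearing on this place is a 1.1-fold higher number from compound 1 to compound 3 (0.03 log units; within the scatter), where the acyl group was also changed in size and the number barely moved. On that basis the step of a 1.2-fold lower number from compound 3 to compound 4 (0.07 log units; within the scatter) is expected, that is, no change beyond the scatter. For compound 4 the estimate in this assay is 11000 nM, with a range from 4500 nM to 28000 nM.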

Compound 4, half-maximal inhibitory concentration: 2700 nM
Beside the measured number, compound 4's estimate is 4.1-fold (0.61 log units) above it; measured number below the stated range.
By their numbers in this assay, from the lowest: compound 2; then compound 4; then compounds 1 and 3 (each within the scatter of the next).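

On the carbonyl carbon of the shared core, this assay does respond to the acyl group: a 4.8-fold lower number from compound 3 to compound 4 (0.68 log units; beyond the scatter) and a 4.4-fold lower number from compound 1 to compound 4 (0.65 log units; beyond the scatter) are both modest but beyond the scatter, whereas a 1.1-fold higher number from compound 1 to compound 3 (0.03 log units; within the scatter) stays within it. For the compounds shown here, the position therefore looked flat only across the open chains methyl and ethyl, which cannot be ordered, and cyclopropyl is the first group here to separate from them, with a three-membered non-aromatic ring of carbon only entering and no hydrogen-bond donor or acceptor added. Nothing available explains this shift, so whether the ring or the added heavy atoms account for it stays undetermined. 

Still open, as far as these compounds go, is whether isopropyl on this carbonyl carbon would match cyclopropyl, which would separate branching from the ring itself, and whether cyclobutyl or a longer chain such as butyl would move the number further in either direction. Going by these compounds alone, compound 2 is linked to this series by no single-place step, so how much of its much lower number can be reached on the shared core remains unknown.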